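Changing the Amino Group of Compound 3

The compounds below may be only part of what the source reports. "The series", "measured", "known", "first", "only" and "open" are said of these compounds alone.

In a functional assay on SK-BR-3 cells (Homo sapiens) for antiproliferative activity (a lower number here means a stronger inhibitor, a higher number a weaker inhibitor), compound 3 `CC(C)=CCc1cc(C(=O)Nc2cc3ccc(OCCCN(C)C4CCCCC4)c(C)c3oc2=O)ccc1O` gives 970 nM. This lies within the scatter of compound 1 `CC(C)=CCc1cc(C(=O)Nc2cc3ccc(OCC4CCCNC4)c(C)c3oc2=O)ccc1O`, which gives 600 nM, while compound 2 `CC(C)=CCc1cc(C(=O)Nc2cc3ccc(OCCCNCC(=O)O)c(C)c3oc2=O)ccc1O` gives 7570 nM. The change leading to compound 4 `CC(C)=CCc1cc(C(=O)Nc2cc3ccc(OCCCNC(C)(C)c4ccccc4)c(C)c3oc2=O)ccc1O` is (1-methyl-1-phenylethyl)amino in place of cyclohexyl(methyl)amino on a saturated chain carbon, three bonds along the chain from an oxygen on an aromatic ring. This places (1-methyl-1-phenylethyl)amino on the saturated chain carbon that carries cyclohexyl(methyl)amino in compound 3.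

Among the measured compounds shown here, no measured step covers this exchange directly, so the evidence is indirect. The step of a 1.6-fold higher number from compound 1 to compound 3 (0.21 log units; within the scatter) shows no change beyond the scatter. The two larger steps both involve compound 2, which carries (carboxymethyl)amino: a 13-fold higher number from compound 1 to compound 2 (1.10 log units; beyond the scatter) and a 7.8-fold lower number from compound 2 to compound 3 (0.89 log units; beyond the scatter). Compound 4 has no carboxymethyl group and, like compound 3, has no net charge, so it is expected to stay with compounds 1 and 3 rather than move toward compound 2. The estimated step, a 1.1-fold lower number from compound 3 to compound 4 (0.06 log units; within the scatter), is therefore not expected to exceed the scatter. For compound 4, the estimated value is 850 nM, with an expected range of 320 nM to 2400 nM.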

Compound 4, half-maximal inhibitory concentration: 960 nM
Estimate against measurement, compound 4: 1.1-fold (0.05 log units) below, within the range that was stated.
By their numbers in this assay, from the lowest: compounds 1, 4 and 3 (each within the scatter of the next); then compound 2.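

In this assay, (1-methyl-1-phenylethyl)amino in place of cyclohexyl(methyl)amino gives a 1.0-fold lower number from compound 3 to compound 4 (0.00 log units; within the scatter), so at this saturated chain carbon an aromatic ring can stand in for a non-aromatic one, and a hydrogen-bond donor can be added, with no change beyond the scatter. The comparison with the piperidin-3-yl group gives a 1.6-fold higher number from compound 1 to compound 4 (0.20 log units; within the scatter), while the comparison with the carboxymethyl group on the amine nitrogen gives a 7.9-fold lower number from compound 2 to compound 4 (0.90 log units; beyond the scatter), which leaves carboxymethyl as the only group shown that stands apart beyond the scatter. Nothing available explains why these groups behave alike.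

As far as these compounds go, it remains open whether a small amine such as dimethylamino, or a longer chain carrying the same amine, would stay within this range. From the compounds shown here alone, it is also open whether a benzylamine would do so.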